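A few compounds are considered here, and "the series" means these few. Any claim that something is new, unique, unknown or untested is made for them only; others in the source may bear on it.

Measured so far:
- Compound 1 `COc1ccc(/C=C/C(=O)c2c(C)[n+]([O-])c3ccccc3[n+]2[O-])cc1`: 27600 nM
- Compound 2 `COc1ccc(/C=C/C(=O)c2c(C)[n+]([O-])c3ccccc3[n+]2[O-])cc1OC`: 19200 nM
- Compound 3 `Cc1ccc(/C=C/C(=O)c2c(C)[n+]([O-])c3ccccc3[n+]2[O-])cc1`: 22400 nM

These three share one core and differ only in the groups on the aromatic ring of the side chain. In a functional assay on CCRF-CEM cells (Homo sapiens) for inhibition, with a stated time of 3 days (a higher number here means a weaker inhibitor, a lower number a stronger inhibitor), compound 2 gives the smallest number of the three, yet compound 1 and compound 3 both lie within the scatter of it, so no order among them can be claimed.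

Compound 4 `COc1cc(/C=C/C(=O)c2c(C)[n+]([O-])c3ccccc3[n+]2[O-])cc(OC)c1OC` is the next step from compound 2: methoxy in place of hydrogen on an aromatic carbon. The closest measured precedent is the same kind of addition going from compound 1 to compound 2, which gave a 1.4-fold lower number from compound 1 to compound 2 (0.16 log units; within the scatter). On that basis the expected step from compound 2 to compound 4 in this assay is a 1.1-fold lower number from compound 2 to compound 4 (0.05 log units; within the scatter), that is, nothing beyond the scatter. Compound 4 is therefore estimated at 17000 nM, with a likely range from 8000 nM to 36000 nM.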

Compound 4, half-maximal inhibitory concentration: 5220 nM
Compound 4: middle estimate off by 3.3-fold (0.51 log units), on the high side, and the stated range ends above it.
By their numbers in this assay, from the lowest: compound 4; then compounds 2, 3 and 1 (each within the scatter of the next).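

Methoxy in place of hydrogen on an aromatic carbon now gives a step beyond the scatter in this assay: a 3.7-fold lower number from compound 2 to compound 4 (0.57 log units; beyond the scatter). Going by these compounds alone, the same kind of change earlier gave a 1.4-fold lower number from compound 1 to compound 2 (0.16 log units; within the scatter), which lies within the scatter, so on this ring the same swap need not give a step of the same size, and this place, ortho to a methoxy group, is the first to show a clear step. Nothing available explains this difference.

On these data alone, whether methoxy itself is needed at this place remains open. A hydroxyl, an amine or a longer chain such as ethoxy could give a different result there.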